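The source may report more compounds than this note shows. Statements on the series, on what has been measured and on what is new or still open speak of the compounds shown alone.

Of the compounds shown here, two built on a shared core have been tested in a functional assay (trachea) with Rattus norvegicus as the target; a higher number here means a more potent compound, by a factor of ten per unit of this negative logarithm, a lower number a less potent compound. Compound 1 `CC(=O)Oc1ccc2c(c1)C(n1ccccc1=O)=CC(C)(C)O2` gives 4.97, and compound 2 `CC1(C)C=C(n2ccccc2=O)c2cc(OC(=O)Nc3ccccc3)ccc2O1` gives 4.89. The two numbers lie within the usual scatter of each other, so neither can be called the more potent. Going by the values given here, the only step measured so far, anilino in place of methyl on a carbonyl carbon, reads a number 0.08 log units lower from compound 1 to compound 2 (within the scatter).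

Compound 3 `CC1(C)C=C(n2ccccc2=O)c2cc(OC(=O)Nc3ccccc3F)ccc2O1` differs from compound 2 by fluoro in place of hydrogen on an aromatic carbon. The fluoro group enters on an aromatic carbon of a six-membered aromatic ring of carbon only, ortho to a large group. Among the compounds with values here, no measured step touches this ring, and the one step that is known changed a different part of the molecule without moving the number beyond the scatter. The expected step is therefore a number 0.01 log units higher from compound 2 to compound 3 (within the scatter). Compound 3 is expected to give about 4.9, most likely between 4.3 and 5.5.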

Compound 3, logarithm of the reciprocal of the active concentration, log(1/C): 4.22
Compound 3: the middle estimate sits 0.68 log units above what was measured; the whole stated range lies above it.
By their numbers in this assay, from the lowest: compound 3; then compounds 2 and 1 (each within the scatter of the next).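

In this assay the phenyl ring of the anilino group turns out not to be a silent part of the molecule: one fluoro on an aromatic carbon, ortho to a large group, gives a number 0.67 log units lower from compound 2 to compound 3 (beyond the scatter). Replacing the methyl on the carbonyl carbon with (2-fluorophenyl)amino gives a number 0.75 log units lower from compound 1 to compound 3 (beyond the scatter), so the tolerance seen for plain anilino in that place does not carry over to its fluorinated form. Nothing at hand bears on why the number falls.

As far as these compounds go, it stays open whether the loss belongs to fluoro itself or to its place on the ring. A chloro or methyl group on the same carbon, or a fluoro elsewhere on this ring, would separate those two readings.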